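The source may report more compounds than this note shows. Statements on the series, on what has been measured and on what is new or still open speak of the compounds shown alone.

Compound 1 `COc1cc(C(=O)/C=C/c2cc(-c3cc(OC)c(OC)c(OC)c3)n3nc(-c4ccccc4)cc3n2)cc(OC)c1OC` gives 24300 nM in a functional assay on MDA-MB-231 cells (Homo sapiens) for antiproliferative activity, read by MTT assay, with a stated time of 24 h; a higher number here means a weaker inhibitor, a lower number a stronger inhibitor; compound 2 `COc1ccc(-c2cc(/C=C/C(=O)c3cc(OC)c(OC)c(OC)c3)nc3cc(-c4ccccc4)nn23)cc1OC` gives 4700 nM.

Compound 1 stands at the higher of the two numbers, compound 2 being the nearer and only neighbour with a 5.2-fold lower number from compound 1 to compound 2 (0.71 log units; beyond the scatter). Compound 3 `COc1ccc(C(=O)/C=C/c2cc(-c3cc(OC)c(OC)c(OC)c3)n3nc(-c4ccccc4)cc3n2)cc1OC` differs from compound 1 by hydrogen in place of methoxy on an aromatic carbon, a change of 3,4,5-trimethoxyphenyl to 3,4-dimethoxyphenyl. Among the compounds with values here, the one step known, from compound 1 to compound 2, is the same kind of change on the other aryl ring and was modest. A modest step downward is therefore expected, as a 2.4-fold lower number from compound 1 to compound 3 (0.39 log units; beyond the scatter), and compound 3 is estimated at 10000 nM within 3000 nM to 30000 nM.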

Compound 3, half-maximal inhibitory concentration: 18300 nM
Beside the measured number, compound 3's estimate is 1.8-fold (0.26 log units) below it, within the range that was stated.
By their numbers in this assay, from the lowest: compound 2; then compounds 3 and 1 (each within the scatter of the next).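

In this assay, the change of 3,4,5-trimethoxyphenyl to 3,4-dimethoxyphenyl on this ring gives (a 1.3-fold lower number from compound 1 to compound 3 (0.12 log units; within the scatter)), so compound 3 cannot be told apart from compound 1. The same kind of change on the other ring gave (a 5.2-fold lower number from compound 1 to compound 2 (0.71 log units; beyond the scatter)), so replacing methoxy with hydrogen does not read the same on the two rings. Nothing given here accounts for this difference. From the compounds shown here alone, whether an amine, a hydroxyl or a fluorine in this place would shift the number stays open.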